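This account rests on a few compounds, and the source may have more. Where it says the series, first, only, none or still open, it means among the compounds named here.

In a physicochemical assay for solubility, in phosphate buffer, measured as kinetic solubility, at pH 7.4 (on this read-out lower numbers stand for lower solubility and higher numbers for higher solubility), compound 3 `COc1cccc(Cl)c1-c1nc(CN2CCC(C(=O)NCCCN3C[C@H](C)C[C@H](C)C3)CC2)c(C)o1` gives > 76 ug/mL, which is a limit and not a number. Compound 1 `Cc1oc(-c2c(Cl)cccc2Cl)nc1CN1CCC(C(=O)NCCCN2C[C@H](C)C[C@H](C)C2)CC1` gives > 77 ug/mL, also a limit. Compound 2 `Cc1cccc(F)c1-c1nc(CN2CCC(C(=O)NCCCN3C[C@H](C)C[C@H](C)C3)CC2)c(C)o1` gives > 72 ug/mL, again a limit. Compound 4 `Cc1cccc(C)c1-c1nc(CN2CCC(C(=O)NCCCN3C[C@H](C)C[C@H](C)C3)CC2)c(C)o1` differs from compound 3 by one change, (2,6-dimethylphenyl in place of 2-chloro-6-methoxyphenyl on an aromatic carbon), with 2,6-dimethylphenyl in place of 2-chloro-6-methoxyphenyl on an aromatic carbon. Three measured steps also exchange groups on an aromatic carbon, but none has a readable size: a step that the two limits leave unreadable from compound 1 to compound 2, a step that the two limits leave unreadable from compound 1 to compound 3 and a step that the two limits leave unreadable from compound 2 to compound 3. They therefore offer no direction, and no step beyond the scatter is expected in this assay. The expected step is an at least 1.0-fold lower number from compound 3 to compound 4 (0.00 log units; that floor lies within the scatter). Compound 4 is estimated at 75 ug/mL, with an expected range of 55 ug/mL to 95 ug/mL.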

Compound 4, solubility: 55.9 ug/mL
Estimate against measurement, compound 4: 1.3-fold (0.13 log units) above, within the range that was stated.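

In this assay compound 4 is the only one shown that gives a number rather than a limit, 55.9 ug/mL. Set against the other three compounds, 2,6-dimethylphenyl at this position gives an at least 1.3-fold lower number from compound 3 to compound 4 (0.13 log units; that floor lies within the scatter), an at least 1.2-fold lower number from compound 2 to compound 4 (0.10 log units; that floor lies within the scatter) and an at least 1.3-fold lower number from compound 1 to compound 4 (0.13 log units; that floor lies within the scatter). Each step starts from a limit and is only a floor, so its full size cannot be read.

As far as these compounds go, whether the real steps go beyond the scatter remains open. So does how a hydroxyl or a dimethylamino group on this phenyl ring would read.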